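Dropping the Ether Oxygen in a Bile Acid Receptor Series

The source may hold more compounds than are shown below. What is called first, only, known or untested is meant among the compounds shown, and "the series" means these compounds.

Three amides built on a shared core have been tested in an assay on isolated protein for agonist activity at Bile acid receptor (Homo sapiens), read by TR-FRET, with a stated time of 3 h, in the absence of a further agent; a higher number here means that more compound is needed for the effect, a lower number that less compound is needed. Compound 1 `CCCOc1cccc(C(=O)Nc2cccc(C(=O)O)c2)c1` gives 2150 nM. Compound 2 `O=C(O)c1cccc(NC(=O)c2cccc(OCc3ccccc3)c2)c1` gives 1160 nM, and compound 3 `Cc1ccc(COc2cccc(C(=O)Nc3cccc(C(=O)O)c3)c2)cc1` gives 1430 nM. Among these three numbers compound 3 stands second highest, with compound 2 as its nearest neighbour and compound 1 as its furthest, yet all three lie within the scatter of one another, so none of them can be called stronger or weaker than another. The measured steps show the same picture: a 1.9-fold lower number from compound 1 to compound 2 (0.27 log units; within the scatter), a 1.5-fold lower number from compound 1 to compound 3 (0.18 log units; within the scatter) and a 1.2-fold higher number from compound 2 to compound 3 (0.09 log units; within the scatter).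

Compound 4 `Cc1ccccc1-c1cccc(C(=O)Nc2cccc(C(=O)O)c2)c1` is not yet measured. The change is 2-methylphenyl in place of (4-methylbenzyl)oxy on an aromatic carbon. Within the data shown here, every measured step so far varied the group hanging on the ether oxygen while keeping that oxygen and its saturated carbon in place; none removed them to join a ring directly to the core. Among the measured compounds shown here, no measured step therefore bears on this change, and the three values only show that exchanging groups there has moved nothing beyond the scatter. The expectation is a step of a 1.4-fold higher number from compound 3 to compound 4 (0.15 log units; within the scatter) that stays within the scatter, held with wide uncertainty. Compound 4 is estimated at 2000 nM, with a range from 500 nM to 8000 nM.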

Compound 4, half-maximal effective concentration: 68 nM
Estimate against measurement, compound 4: 29-fold (1.47 log units) above; the whole stated range lies above it.
By their numbers in this assay, from the lowest: compound 4; then compounds 2, 3 and 1 (each within the scatter of the next).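

On this aromatic carbon, meta to a large group, the propoxy, benzyloxy and (4-methylbenzyl)oxy groups of compound 1, compound 2 and compound 3 gave numbers within the scatter of one another, which could have suggested that the position hardly matters, but a directly joined 2-methylphenyl group shows otherwise in this assay (there is a 21-fold lower number from compound 3 to compound 4 (1.32 log units; beyond the scatter) and a 17-fold lower number from compound 2 to compound 4 (1.23 log units; beyond the scatter) and a 32-fold lower number from compound 1 to compound 4 (1.50 log units; beyond the scatter)). The position therefore does respond to what it carries, and in these compounds the large response appears only when the ether oxygen and its saturated carbon leave, not when the group on that oxygen is exchanged. Nothing shown gives a reason for this step.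

The change removes the ether link and brings in a methyl on the new ring in a different place, so the compounds shown cannot tell which of these accounts for the lower number. A directly joined plain phenyl or 4-methylphenyl group would separate the two, and a chlorine or a methoxy group in place of that methyl would show whether the methyl itself matters.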